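The source may hold more compounds than are shown below. What is called first, only, known or untested is meant among the compounds shown, and "the series" means these compounds.

Three compounds sharing one core were tested in a functional assay on A549 cells (Homo sapiens) for cytotoxicity, read by MTT assay, with a stated time of 72 h; a lower number here means a stronger inhibitor, a higher number a weaker inhibitor. Compound 1 `O=C(Nc1ccc(Oc2ccnc3[nH]ccc23)cc1)c1nn(-c2ccc(Br)cc2F)ccc1=O` gives 26100 nM in this assay, the highest of the three numbers. Compound 2 `O=C(Nc1ccc(Oc2ccnc3[nH]ccc23)cc1)c1nn(-c2ccc(Cl)c(F)c2)ccc1=O` gives 2580 nM, and compound 3 `O=C(Nc1ccc(Oc2ccnc3[nH]ccc23)cc1)c1nn(-c2ccc(Cl)c(C(F)(F)F)c2)ccc1=O` gives 2190 nM. The two measured steps that leave compound 1 are both large: a 10-fold lower number from compound 1 to compound 2 (1.01 log units; beyond the scatter) and a 12-fold lower number from compound 1 to compound 3 (1.08 log units; beyond the scatter), each exchanging the aryl group on the aromatic nitrogen. Between compound 2 and compound 3 the change is a 1.2-fold lower number from compound 2 to compound 3 (0.07 log units; within the scatter).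

Compound 4 `O=C(Nc1ccc(Oc2ccnc3[nH]ccc23)c(F)c1)c1nn(-c2ccc(Br)cc2F)ccc1=O` differs from compound 1 elsewhere: fluoro in place of hydrogen on an aromatic carbon, on the ring bearing the amide nitrogen rather than on the aryl group on the aromatic nitrogen. Among the compounds with values here, none of the measured steps touches this ring, so the only knowledge here is that changes at the other end of compound 1 in this assay were large, whereas nothing shows how this ring responds to a single fluoro. Within the data shown here, with no step bearing on the change, the expected outcome from compound 1 to compound 4 is a 1.2-fold lower number from compound 1 to compound 4 (0.07 log units; within the scatter), that is, no step beyond the scatter. Compound 4 is therefore estimated at 22000 nM in this assay, within a range of 7000 nM to 70000 nM.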

Compound 4, half-maximal inhibitory concentration: 55700 nM
Estimate against measurement, compound 4: 2.5-fold (0.40 log units) below; measured number inside the range.
By their numbers in this assay, from the lowest: compounds 3 and 2 (each within the scatter of the next); then compound 1; then compound 4.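

Within the data shown here, the ring bearing the amide nitrogen, untouched by the earlier steps, turns out to respond in this assay: a single fluoro, placed ortho to a large group and meta to a large group, gives a 2.1-fold higher number from compound 1 to compound 4 (0.33 log units; beyond the scatter). Among these compounds, this is the first measured step that raises the number, although the step is modest, whereas the exchanges of the aryl group on the aromatic nitrogen were large and lowered it. Nothing given here explains why this fluoro raises the number.

This single pair cannot show whether the same fluoro would shift the number in the same direction and by a similar amount if it were placed on compound 2 or compound 3, which carry different aryl groups on the aromatic nitrogen. It also leaves open how a chloro, a methyl, a methoxy or an amine on the same aromatic carbon would compare with the hydrogen of compound 1, and so whether the rise belongs to fluoro alone or to any group at this place.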